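A methoxy group on the sulfonyl-bound ring of compound 3

This account rests on a few compounds, and the source may have more. Where it says the series, first, only, none or still open, it means among the compounds named here.

Three compounds sharing one core have numbers in a functional assay on PC-3 cells (Homo sapiens) for cytotoxicity, read by MTT assay, with a stated time of 72 h; a higher number here means a weaker inhibitor, a lower number a stronger inhibitor. Compound 1 `Cc1ccc(S(=O)(=O)c2nc3ccccc3nc2N2CCCC2)cc1` reports only a limit of the assay, > 50000 nM, and not a number. Compound 2 `O=S(=O)(c1ccc(F)cc1)c1nc2ccccc2nc1N1CCCC1` gives 12400 nM, while compound 3 `O=S(=O)(c1ccccc1)c1nc2ccccc2nc1N1CCc2ccccc2C1` gives 5010 nM, the lowest of the two numbers shown; the gap of compound 3 to compound 2 lies beyond the scatter. Compound 4 `COc1ccc(S(=O)(=O)c2nc3ccccc3nc2N2CCc3ccccc3C2)cc1` carries the change (methoxy in place of hydrogen on an aromatic carbon). Within the data shown here, only one measured step touches the same ring: the step of an at least 4.0-fold lower number from compound 1 to compound 2 (0.60 log units; beyond the scatter), which swapped one group for another on that aromatic carbon and was at least modest, its size bounded because compound 1 sits at the limit of > 50000 nM in this assay, at which 1 of the 3 values shown sits. That step does not compare hydrogen with a substituent, so it gives no direction for compound 4. A step of no size beyond the scatter is therefore expected, so that a 1.0-fold lower number from compound 3 to compound 4 (0.00 log units; within the scatter) is what is estimated. Compound 4 is expected to give 5000 nM in this assay, within a range from 1500 nM to 16000 nM.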

Compound 4, half-maximal inhibitory concentration: > 50000 nM
Compound 4 gave a limit, no number (the forecaster's own chance of this, stated with the estimate: 5%); middle value at least 10-fold (1.00 log units) away from the limit.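

In this assay, methoxy in place of hydrogen gives an at least 9.9-fold higher number from compound 3 to compound 4 (0.99 log units; beyond the scatter), the first step shown that sets hydrogen against a substituent on this aromatic carbon, para to a large group. Compound 4 gives > 50000 nM, which is a limit and not a number, so this step has only a lower bound and its full size cannot be read. With this step and an at least 4.0-fold lower number from compound 1 to compound 2 (0.60 log units; beyond the scatter), both measured changes on this ring carbon lie beyond the scatter, and the limit now bounds more of the series: the limit of > 50000 nM in this assay, at which 2 of the 4 values shown sit.

As far as these compounds go, how far compound 4 lies past the limit stays open. The compounds shown also leave open how a hydroxyl group, an amine or a carboxylic acid at this place on compound 3 would compare with hydrogen and methoxy.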